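The source may report more compounds than this note shows. Statements on the series, on what has been measured and on what is new or still open speak of the compounds shown alone.

Series notes. The shared core carries a benzylamide and an alkylamine on one side and a substituted piperazine on the other. Compound 1 `CC(C)CNc1nc(N2CCN(Cc3ccccc3)CC2)ncc1C(=O)NCc1ccccc1` in a functional assay on HEK293 cells for agonist activity at transient receptor potential cation channel subfamily A member 1 (Homo sapiens), read by fluorescence and calcium flux, with stated times of 1 s and 60 s (a higher number here means that more compound is needed for the effect, a lower number that less compound is needed), gives 79 nM. Compound 2 `CC(C)CNc1nc(N2CCN(Cc3ccccc3)CC2)ncc1C(=O)NCc1ccccn1` in this assay is reported as "not active" (no number reported), with no number attached. Compound 3 `O=C(NCc1ccccc1)c1cnc(N2CCN(C(=O)c3c(F)cccc3F)CC2)nc1NC1CC1` in this assay gives 27 nM, the lower of the two numbers in hand; compound 1 stands higher, and that gap lies beyond the usual scatter. Compound 3 and compound 1 differ in more than one place, so the two values show only this order, not a single effect.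

The next step leads to compound 4 `CCCCN1CCN(c2ncc(C(=O)NCc3ccccc3)c(NC3CC3)n2)CC1`. Change from compound 3: butyl in place of (2,6-difluorophenyl)carbonyl on an amine nitrogen in a ring. The amide linkage and the aromatic ring on the piperazine nitrogen both go, and a plain chain enters. Going by the values given here, no measured pair in the set isolates this change, so its size is uncertain. Compound 4 in this assay is expected to come out somewhat higher than compound 3, a step of a 3.0-fold higher number from compound 3 to compound 4 (0.47 log units; beyond the scatter), given that compound 3 at 27 nM holds the lowest number seen. The estimate for compound 4 is 80 nM, with a range from 20 nM to 400 nM.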

Compound 4, half-maximal effective concentration: "not active" (no number reported)
For compound 4 the study gives words and no number, and the estimate cannot be compared.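

Going by these compounds alone, compound 4 carries words and no number in [ this assay ], so no step from compound 3 to compound 4 can be read. No measured evidence bears on this result. The compounds shown leave open how other groups on that amine nitrogen in a ring would read out, with the remaining parts of compound 3 unchanged.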